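Pyridinyloxy for Azetidinyl on the Pyridine Ring of Compound 3

The source may report more compounds than this note shows. Statements on the series, on what has been measured and on what is new or still open speak of the compounds shown alone.

Compounds measured so far:
- compound 1 `Clc1cccc(-n2ncnc2NCc2cccnc2)c1Cl`: 1320 nM
- compound 2 `Cc1ncccc1CNc1ncnn1-c1cccc(Cl)c1Cl`: 295 nM
- compound 3 `Clc1cccc(-n2ncnc2NCc2cccnc2N2CCC2)c1Cl`: 25.7 nM

These three compounds share a common core and differ only in the group on one aromatic carbon of the pyridine ring. In a functional assay for antagonist activity at P2X purinoceptor 7 (Rattus norvegicus), read by FLIPR and calcium flux (on this read-out higher numbers stand for weaker inhibition and lower numbers for stronger inhibition), compound 1 gives 1320 nM, compound 2 gives 295 nM, and compound 3 gives 25.7 nM. Compound 3 stands lowest of the three numbers; its nearest neighbour is compound 2 an 11-fold lower number from compound 2 to compound 3 (1.06 log units; beyond the scatter), and its furthest is compound 1 a 51-fold lower number from compound 1 to compound 3 (1.71 log units; beyond the scatter). Both steps lie beyond the scatter, and the step from hydrogen to methyl a 4.5-fold lower number from compound 1 to compound 2 (0.65 log units; beyond the scatter) is modest by comparison.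

Compound 4 `Clc1cccc(-n2ncnc2NCc2cccnc2Oc2cccnc2)c1Cl` is not yet measured. It differs from compound 3 in one place: (pyridin-3-yl)oxy in place of azetidin-1-yl on an aromatic carbon. The group sits on an aromatic carbon of a six-membered aromatic ring with one nitrogen, next to the ring nitrogen, ortho to a large group.

The measured steps show that placing a substituent at this position, whether methyl or azetidin-1-yl, lowers the number in this assay, and the larger of the two groups gave the lower number. Going by the values given here, no measured step covers an aryl ether at this position, so the size of the change from azetidin-1-yl to (pyridin-3-yl)oxy is open. Compound 4 is expected to keep a number below that of compound 1 but probably somewhat above that of compound 3, an estimated step of a 3.1-fold higher number from compound 3 to compound 4 (0.49 log units; beyond the scatter). The estimate for compound 4 is 80 nM, with a range from 15 nM to 400 nM.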

Compound 4, half-maximal inhibitory concentration: 129 nM
The estimate for compound 4 lay 1.6-fold (0.21 log units) below the measured number, and the stated range covers the measured number.
By their numbers in this assay, from the lowest: compound 3; then compound 4; then compound 2; then compound 1.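

In this assay, (pyridin-3-yl)oxy on this aromatic carbon next to the ring nitrogen still gives a lower number than hydrogen, a 10-fold lower number from compound 1 to compound 4 (1.01 log units; beyond the scatter), and than methyl, a 2.3-fold lower number from compound 2 to compound 4 (0.36 log units; beyond the scatter), so an aryl ether is also tolerated here and a substituent at this carbon again beats hydrogen. Going by these compounds alone, it does not match azetidin-1-yl, however, a 5.0-fold higher number from compound 3 to compound 4 (0.70 log units; beyond the scatter), and compound 4 therefore goes against the reading from the first three compounds that the larger group gives the lower number: size alone does not set the order at this position. Nothing available bears on why the aryl ether falls short of the azetidine.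

The compounds shown leave open whether the loss from compound 3 to compound 4 belongs to the ether oxygen or to the pyridine ring it carries, a question that a methoxy group, a phenoxy group or a pyridin-3-ylamino group on this carbon would help to separate. From the compounds shown here alone, it also remains open how other cyclic amines, such as pyrrolidin-1-yl or piperidin-1-yl, would compare with azetidin-1-yl.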